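This account rests on a few compounds, and the source may have more. Where it says the series, first, only, none or still open, it means among the compounds named here.

In a functional assay on the whole organism (strain Wistar) for inhibition, with Rattus norvegicus as the target, read by paw edema, with a stated time of 4 h, at a dose of 10 mg/kg by the intraperitoneal route (on this read-out higher numbers stand for more inhibition at the one dose given (going by the name of the read-out) and lower numbers for less inhibition), compound 1 `O=C(N/N=C/c1cccc(O)c1)c1cccnc1Nc1cccc(C(F)(F)F)c1` gives 35.8%. Compound 2 `COc1cc(/C=N/NC(=O)c2cccnc2Nc2cccc(C(F)(F)F)c2)cc(OC)c1OC` gives 28.6% in this assay, so compound 1 holds the larger of the two numbers, though the gap between them lies within the usual scatter of such measurements. Compound 3 `O=C(N/N=C/c1cccnc1)c1cccnc1Nc1cccc(C(F)(F)F)c1` differs from compound 1 in one place: pyridin-3-yl in place of 3-hydroxyphenyl on a carbon with a double bond to nitrogen. Among the compounds with values here, no pair of measured compounds shows a change of this kind, so its effect on the read-out is unknown. A shift of modest size at most, in either direction, is expected, and the step of a number 5.8 percentage points lower from compound 1 to compound 3 (within the scatter) is that estimate. Compound 3 is expected to give about 30% in this assay, between 15% and 45%.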

Compound 3, a percentage reported as inhibition, in the whole organism at one dose (the size of the read-out at that dose, not a potency): 36%
Compound 3: the middle estimate sits 6 percentage points below what was measured; the measured number falls inside the stated range.
By their numbers in this assay, from the lowest: compounds 2, 1 and 3 (each within the scatter of the next).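

Replacing 3-hydroxyphenyl with pyridin-3-yl on a carbon with a double bond to nitrogen gives a number 0.2 percentage points higher from compound 1 to compound 3 (within the scatter) in this assay. This position therefore accepts a ring nitrogen and the loss of the hydroxyl's hydrogen-bond donor with no change in the read-out beyond the scatter. No measurement at hand explains why the two groups read alike. Going by these compounds, whether a non-aromatic group here, such as a piperidine ring or a longer alkyl chain, would hold the read-out stays open. So does the effect of a carboxylic acid on the ring.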